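Lengthening the hydroxycarbamoyl chain of compound 1

A few compounds are considered here, and "the series" means these few. Any claim that something is new, unique, unknown or untested is made for them only; others in the source may bear on it.

Compound 1 `Nc1nc2cc(-c3nn(CCCC(=O)NO)c4ncnc(N)c34)ccc2o1` offers no exact starting number in a functional assay on CNE-2 cells (Homo sapiens) for inhibition, read by MTT assay, with a stated time of 72 h; on this read-out higher numbers stand for weaker inhibition and lower numbers for stronger inhibition. Compound 1 reads > 50000 nM, which is a limit of the assay. Compound 2 `Nc1ncnc2c1c(-c1cnc3[nH]ccc3c1)nn2CCCCCC(=O)NO` reads > 50000 nM, also a limit. The picture so far is therefore dominated by the limit of > 50000 nM in this assay, at which 2 of the 3 values shown sit. Sharing its core with compound 2, compound 3 `Nc1ncnc2c1c(-c1cnc3[nH]ccc3c1)nn2CCCCCCC(=O)NO` gives 19500 nM, the only exact number available.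

Compound 4 `Nc1nc2cc(-c3nn(CCCCCC(=O)NO)c4ncnc(N)c34)ccc2o1` keeps the core of compound 1 and extends its chain: 2-(hydroxycarbamoyl)ethyl in place of hydroxycarbamoyl on a saturated chain carbon, three bonds along the chain from an aromatic nitrogen. Here 2-(hydroxycarbamoyl)ethyl replaces hydroxycarbamoyl on a saturated chain carbon, three bonds along the chain from an aromatic nitrogen.

Among the measured compounds shown here, the one measured step that bears on this also lengthens the chain, though on the other core, and it lies beyond the scatter: an at least 2.5-fold lower number from compound 2 to compound 3 (0.40 log units; beyond the scatter). On the strength of that step from compound 2 to compound 3, a modest fall in the number is expected in this assay, though compound 4 may well stay at the limit. The expected change is an at least 2.0-fold lower number from compound 1 to compound 4 (0.30 log units; that floor lies within the scatter). For compound 4 the estimate is 25000 nM, within a range of 8000 nM to 50000 nM.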

Compound 4, half-maximal inhibitory concentration: 37600 nM
Estimate against measurement, compound 4: 1.5-fold (0.18 log units) below; measured number inside the range.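

Among the compounds shown here, with the longer chain, the core shared by compound 1 and compound 4 now has an exact reading in this assay, which none of the earlier compounds gave for this core. Putting 2-(hydroxycarbamoyl)ethyl in place of hydroxycarbamoyl at this position gives an at least 1.3-fold lower number from compound 1 to compound 4 (0.12 log units; that floor lies within the scatter), so the data cannot yet show whether the change has a real effect on this core, although the true step could be larger than that floor. The exact reading also leaves the series bounded by a limit of the assay: the limit of > 50000 nM in this assay, at which 2 of the 4 values shown sit.

The compounds shown leave open whether a still longer chain on this core would bring the number down further. They also leave open whether a carboxylic acid in place of the hydroxycarbamoyl end would keep any of the inhibition.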